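The source may report more compounds than this note shows. Statements on the series, on what has been measured and on what is new or still open speak of the compounds shown alone.

In a functional assay on HUVEC cells (Homo sapiens) for antiproliferative activity, read by MTT assay, with a stated time of 24 h (a higher number here means a weaker inhibitor, a lower number a stronger inhibitor), compound 2 (`COc1cc(OC)c(-c2coc3cc(OCC(=O)c4cccc(C(F)(F)F)c4)ccc3c2=O)cc1OC`) gives > 10000 nM, a limit and not a number. Compound 1 (`C#CCOc1ccc2c(=O)c(-c3cc(OC)c(OC)cc3OC)coc2c1`) gives > 10000 nM, also a limit. For the measured compounds named here, the one measured step, a step that the two limits leave unreadable from compound 1 to compound 2, has no readable size, and the evidence stops at the limit of > 10000 nM in this assay, at which 2 of the 2 values shown sit. Compound 3 (`COc1cc(OC)c(-c2coc3cc(OCc4ccccc4F)ccc3c2=O)cc1OC`) carries 2-fluorophenyl in place of (3-(trifluoromethyl)phenyl)carbonyl on a saturated chain carbon bound to an oxygen on an aromatic ring. Given a step that the two limits leave unreadable from compound 1 to compound 2, no step beyond the scatter in either direction is expected, and the estimated step is a step that the limit leaves unreadable from compound 2 to compound 3. For compound 3 the estimate is 12000 nM, expected between 3000 nM and 40000 nM.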

Compound 3, half-maximal inhibitory concentration: 4300 nM
The estimate for compound 3 lay 2.8-fold (0.45 log units) above the measured number; the measured number falls inside the stated range.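

Compound 3 is the only compound shown with a number rather than a limit in this assay, so the group on this saturated chain carbon can change the read-out. 2-Fluorophenyl gives an at least 2.3-fold lower number from compound 2 to compound 3 (0.36 log units; beyond the scatter), and, against ethynyl, an at least 2.3-fold lower number from compound 1 to compound 3 (0.36 log units; beyond the scatter). Both steps start from a limit, so their full size stays unread: the limit of > 10000 nM in this assay, at which 2 of the 3 values shown sit.

On these data alone, the step from compound 2 to compound 3 changes the carbonyl, the trifluoromethyl and the fluorine together, so their separate shares remain open. As far as these compounds go, how a plain phenyl or a chain ending in an amine would read here also remains open.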